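Removing a Methyl From an Inactive Amide Series

This account rests on a few compounds, and the source may have more. Where it says the series, first, only, none or still open, it means among the compounds named here.

Compound 1 `CC1CCN(C(=O)CCNC(=O)c2ccc(S(C)(=O)=O)c([N+](=O)[O-])c2)CC1`: > 60000 nM
Compound 2 `CN(CC(=O)N1CCN(c2ccc(F)cc2)CC1)C(=O)c1ccc(S(C)(=O)=O)c([N+](=O)[O-])c1`: > 60000 nM
Compound 3 `CS(=O)(=O)c1ccc(C(=O)N2CCC(C(=O)N3CCc4ccccc4C3)CC2)cc1[N+](=O)[O-]`: > 60000 nM

These three compounds were tested in an assay on isolated protein for inhibition of vitamin D3 receptor (Homo sapiens), read by fluorescence polarization; a lower number here means a stronger inhibitor, a higher number a weaker inhibitor. The value given for compound 1 is a limit of the assay and not a number. The value given for compound 2 is likewise a limit. The value given for compound 3 is a limit as well. Among the compounds with values here, every reading in this set therefore sits at the limit of > 60000 nM in this assay, at which 3 of the 3 values shown sit, so compound 1 cannot be placed above or below any other compound: all that is known is that none of the three reached a measurable inhibition, and no step between measured compounds can be described.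

Compound 4 `CS(=O)(=O)c1ccc(C(=O)NCCC(=O)N2CCCCC2)cc1[N+](=O)[O-]` has not been measured in this assay. It differs from compound 1 in a single place: hydrogen in place of methyl on a saturated ring carbon. Nothing in the measured set shows what such a change does, since every compound stays at the limit. For that reason no step beyond the scatter is expected, and the estimated step of a number no higher from compound 1 to compound 4 (the limit leaves the size open) is essentially none. Compound 4 is expected to give about 60000 nM, within a range from 20000 nM to 200000 nM, and the assay will most probably again report only a limit.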

Compound 4, half-maximal inhibitory concentration: > 60000 nM
Compound 4: only a limit was reported; the forecaster's own chance of this, stated with the estimate: 85%; the middle value sits exactly at the limit.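

No step can be read from compound 1 to compound 4, so swapping 4-methylpiperidin-1-yl for piperidin-1-yl has no visible size, as both readings are limits and not numbers: the limit of > 60000 nM in this assay, at which 4 of the 4 values shown sit.

The compounds shown leave open whether this change affects inhibition at all, and which structures would give a true number in this assay.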